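One Aryl Swap on a Shared Core: An Expectation

The source may hold more compounds than are shown below. What is called first, only, known or untested is meant among the compounds shown, and "the series" means these compounds.

Measured compounds:
compound 1 `COc1ccc(C(=O)/C=C/c2ccc(F)cc2)c2c1C=CC(C)(C)O2`: > 10000 nM
compound 2 `COc1ccc(C(=O)/C=C/c2cccc3ccccc23)c2c1C=CC(C)(C)O2`: > 10000 nM

In a functional assay on SW-620 cells (Homo sapiens) for antiproliferative activity, read by MTT assay, with a stated time of 24 h (on this read-out lower numbers stand for stronger inhibition and higher numbers for weaker inhibition), compound 1 gives > 10000 nM, which is a limit of the assay rather than a number. Compound 2 likewise gives > 10000 nM, again only a limit. Going by the values given here, compound 1 thus stands at the limit of > 10000 nM in this assay, at which 2 of the 2 values shown sit, and with no measured pair differing in one place, no step can be sized from the data. Compound 3 `COc1ccc(C(=O)/C=C/c2ccccc2Cl)c2c1C=CC(C)(C)O2` carries 2-chlorophenyl in place of 4-fluorophenyl on a double-bonded chain carbon bound to a double-bonded chain carbon. Since both values shown sit at the limit, the data give no direction for this change, and a step of no more than the scatter is expected. Compound 3 is therefore expected to give 15000 nM, between 4000 nM and 60000 nM. The step from compound 1 to compound 3 that this estimate means is a step that the limit leaves unreadable from compound 1 to compound 3, and it is expected to stay within the scatter, most likely as another limit.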

Compound 3, half-maximal inhibitory concentration: > 10000 nM
Compound 3: no number, only a limit; the forecaster's own chance of this, stated with the estimate: 70%; the middle value does not contradict the limit.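

In this assay compound 3 gives > 10000 nM, a limit and not a number, so no step can be read between compound 1 and compound 3. The compounds shown leave open whether 2-chlorophenyl and 4-fluorophenyl differ at all in this read-out, with every value at one limit: the limit of > 10000 nM in this assay, at which 3 of the 3 values shown sit.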